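This account rests on a few compounds, and the source may have more. Where it says the series, first, only, none or still open, it means among the compounds named here.

Measured compounds:
- compound 1, `Cc1nc2c(N)ncnc2n1[C@@H]1O[C@H](CN(C)CCN)[C@@H](O)[C@H]1O`: 88000 nM
- compound 2, `CN(CCCCON)C[C@H]1O[C@@H](n2c(O)nc3c(N)ncnc32)[C@H](O)[C@@H]1O`: 11 nM

Compound 1 stands at the highest of the two numbers measured in an assay on isolated protein for inhibition of S-adenosylmethionine decarboxylase proenzyme (Homo sapiens); a higher number here means a weaker inhibitor, a lower number a stronger inhibitor; the nearest measured number is that of compound 2, which is far lower, well beyond the usual scatter. Within the data shown here, no single-point step between compound 1 and compound 2 is defined, as the two differ in more than one place, so only their two values are compared here.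

Compound 3, `Cc1nc2c(N)ncnc2n1[C@@H]1O[C@H](CN(C)CC(=O)NN)[C@@H](O)[C@H]1O`, has not yet been measured in this assay. It differs from compound 1 by aminocarbamoyl in place of aminomethyl on a saturated chain carbon bound to an amine nitrogen. Among the measured compounds shown here, no measured pair isolates this change, so the expected size rests on the structures alone.

The step from compound 1 to compound 3 is expected to lower the number by a moderate margin, a 4.4-fold lower number from compound 1 to compound 3 (0.64 log units; beyond the scatter), beyond the scatter but far short of the distance to compound 2. Compound 3 is therefore estimated to give 20000 nM in this assay, within a range from 3000 nM to 100000 nM.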

Compound 3, half-maximal inhibitory concentration: 31000 nM
The estimate for compound 3 lay 1.6-fold (0.19 log units) below the measured number; the range from low to high includes it.
By their numbers in this assay, from the lowest: compound 2; then compound 3; then compound 1.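

In this assay, among these compounds, aminocarbamoyl in place of aminomethyl on a saturated chain carbon bound to an amine nitrogen gives a 2.8-fold lower number from compound 1 to compound 3 (0.45 log units; beyond the scatter), the only single-place change that can be read. The position therefore accepts the larger aminocarbamoyl group, with its added carbonyl, and the number still moves modestly downward rather than upward; cut one bond further out, the same change reads as 2-aminoethyl to (aminocarbamoyl)methyl. Nothing measured here bears on what lies behind this modest step, so it stands as an observation on one pair.

One pair cannot show whether the step belongs to the aminocarbamoyl group as a whole or to only part of it; a carboxylic acid, a primary amide or a longer chain ending in an amine at the same place on the core of compound 1 would separate these possibilities. Also open, going by these compounds, is how much of the far lower number of compound 2, which differs from compound 1 in more than one place, comes from its chain and how much from the rest of its structure.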